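This account rests on a few compounds, and the source may have more. Where it says the series, first, only, none or still open, it means among the compounds named here.

In a functional assay on MT2 cells (Homo sapiens) for cytotoxicity (a lower number here means that less compound is tolerated, a higher number that more compound is tolerated), compound 1 `CCCc1ccc(Nc2nccs2)cc1OCC=C(C)C` gives 23000 nM and compound 2 `CC(C)=CCOc1cc(Nc2nccs2)ccc1C` gives 17000 nM. With only these two numbers available, compound 2 stands level with compound 1, since the two values lie within the scatter of each other. Compound 3 `CC(C)=CCOc1cccc(Nc2nccs2)c1` departs from compound 2 by hydrogen in place of methyl on an aromatic carbon. Within the data shown here, one measured step bears on this change: a 1.4-fold lower number from compound 1 to compound 2 (0.13 log units; within the scatter), which put hydrogen in place of ethyl on the saturated chain carbon bound to an aromatic carbon and so shortened the same alkyl group that now leaves entirely. Among the measured compounds shown here, no measured step shows that group removed altogether, so the expectation rests on this single comparison. No change beyond the scatter is therefore expected in this assay, and the estimated 1.2-fold higher number from compound 2 to compound 3 (0.07 log units; within the scatter) reflects that. For compound 3 the expected value is 20000 nM, with an estimated range from 10000 nM to 40000 nM.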

Compound 3, half-maximal cytotoxic concentration: 23000 nM
The estimate for compound 3 lay 1.2-fold (0.06 log units) below the measured number, within the range that was stated.
By their numbers in this assay, from the lowest: compounds 2, 1 and 3 (each within the scatter of the next).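

In this assay, the carbon ortho to the (3-methylbut-2-en-1-yl)oxy group and para to the (1,3-thiazol-2-yl)amino group now carries no alkyl group at all, and replacing methyl there with hydrogen gives a 1.4-fold higher number from compound 2 to compound 3 (0.13 log units; within the scatter) while replacing propyl with hydrogen gives no change at the digits printed from compound 1 to compound 3 (within the scatter) and both steps lie within the scatter. Among these compounds, the earlier compounds compared only two alkyl groups, whereas these steps show that hydrogen, methyl and propyl at this carbon cannot be told apart in this read-out. No measured evidence accounts for this result.

From the compounds shown here alone, whether an amine, a carboxylic acid or a chain longer than propyl at this carbon would move the number beyond the scatter remains open. The (3-methylbut-2-en-1-yl)oxy group and the (1,3-thiazol-2-yl)amino group stay the same throughout, so what replacing either would do is also unknown.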